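Methoxy in place of chloro: working notes on the series

A few compounds are considered here, and "the series" means these few. Any claim that something is new, unique, unknown or untested is made for them only; others in the source may bear on it.

Values in a physicochemical assay for solubility, read by spectrophotometry, in phosphate buffer, measured as kinetic solubility, with a stated time of 18 h, at pH 7.4; on this read-out lower numbers stand for lower solubility and higher numbers for higher solubility:
- Compound 1 `O=C(Nc1cccc(-c2nc3ccccc3s2)c1)c1cc([N+](=O)[O-])ccc1Cl`: 580 nM
- Compound 2 `O=C(Nc1ccc(Cl)c(-c2nc3ccccc3s2)c1)c1cc([N+](=O)[O-])ccc1Cl`: 410 nM
- Compound 3 `COc1ccc(NC(=O)c2cc([N+](=O)[O-])ccc2Cl)cc1-c1nc2ccccc2s1`: not yet measured

Within the data shown here, only two numbers are available so far, and they lie within the scatter of each other, so compound 2 does not stand apart from compound 1. The next comparison is with compound 3, which differs from compound 2 at one place: methoxy in place of chloro on an aromatic carbon. This is methoxy in place of chloro on an aromatic carbon, ortho to a 1,3-benzothiazol-2-yl group and para to a large group. Among the measured compounds shown here, the one measured step at this carbon is a 1.4-fold lower number from compound 1 to compound 2 (0.15 log units; within the scatter), with chloro in place of hydrogen. For the measured compounds named here, no measured compound carries methoxy, so this single step is only a weak guide. On that evidence, no step beyond the scatter is expected in this assay, and no clear direction can be assigned. The estimated step is a 1.1-fold higher number from compound 2 to compound 3 (0.04 log units; within the scatter). The expected value for compound 3 is 450 nM, with an estimated range of 180 nM to 1100 nM.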

Compound 3, solubility: 260 nM
Compound 3: the middle estimate sits 1.7-fold (0.24 log units) above what was measured, within the range that was stated.
By their numbers in this assay, from the lowest: compounds 3, 2 and 1 (each within the scatter of the next, the first and the last beyond it).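

In this assay, methoxy in place of chloro on this aromatic carbon, ortho to a 1,3-benzothiazol-2-yl group and para to a large group, gives a 1.6-fold lower number from compound 2 to compound 3 (0.20 log units; within the scatter) and so does not separate the two groups at this position. Set against hydrogen, however, methoxy gives a 2.2-fold lower number from compound 1 to compound 3 (0.35 log units; beyond the scatter) as the first step in the series beyond the scatter, though a modest one, whereas chloro in place of hydrogen at the same carbon gives a 1.4-fold lower number from compound 1 to compound 2 (0.15 log units; within the scatter) and stays within it. No measurement at hand accounts for this difference between the two steps.

The compounds shown leave open whether an amine, a carboxylic acid or a longer chain such as ethoxy on this carbon would move the number further from that of compound 1 than methoxy does. They also leave open whether the step from hydrogen to methoxy keeps its size when the rest of the molecule changes, since it rests on one pair of compounds on one core.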